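The compounds below may be only part of what the source reports. "The series", "measured", "known", "first", "only" and "open" are said of these compounds alone.

Compound 1, `COc1ccc2[nH]c(-c3ccc(F)cc3)cc(=O)c2c1OC`, gives > 20000 nM in a functional assay on NCI-H460 cells (Homo sapiens) for cytotoxicity, read by MTT assay, with a stated time of 48 h; on this read-out higher numbers stand for weaker inhibition and lower numbers for stronger inhibition; that value is a limit of the assay, not a number. Compound 2, `COc1ccc2[nH]c(-c3ccccc3F)cc(=O)c2c1O`, gives 110 nM. Compound 3, `COc1ccc2[nH]c(-c3ccc(F)cc3)cc(=O)c2c1O`, gives 8800 nM.

Two steps join these compounds. From compound 1 to compound 3 the change is hydrogen in place of methyl on an oxygen on an aromatic ring, and it brings an at least 2.2-fold lower number from compound 1 to compound 3 (0.35 log units; beyond the scatter); since compound 1 sits at the limit of > 20000 nM in this assay, at which 1 of the 3 values shown sits, only the lower bound of this step is known. The other step, an 80-fold higher number from compound 2 to compound 3 (1.90 log units; beyond the scatter), separates compound 2 from compound 3, and compound 2 shows the lowest number of the two measured values. The difference between the cores of compound 1 and compound 2 is not broken down here.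

Compound 4, `O=c1cc(-c2ccccc2F)[nH]c2ccc(O)c(O)c12`, is not yet measured. It differs from compound 2 by hydrogen in place of methyl on an oxygen on an aromatic ring, the same change that leads from compound 1 to compound 3, at the same place. Because the earlier step gave an at least 2.2-fold lower number from compound 1 to compound 3 (0.35 log units; beyond the scatter), a modest lowering of the number is expected here too, and the step from compound 2 to compound 4 is estimated as a 2.2-fold lower number from compound 2 to compound 4 (0.34 log units; beyond the scatter). Compound 4 is therefore expected to give about 50 nM, within roughly 15 nM to 200 nM.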

Compound 4, half-maximal inhibitory concentration: 4100 nM
Estimate against measurement, compound 4: 82-fold (1.91 log units) below, outside the stated range (above it).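

On the core of compound 2, methoxy to hydroxy brings a 37-fold higher number from compound 2 to compound 4 (1.57 log units; beyond the scatter) in this assay, whereas the same change lowered the number on the core of compound 1, so in this series the step does not carry from one core to the other, even in direction: the same change on two cores in this assay, an at least 2.2-fold lower number (0.35 log units; beyond the scatter) from compound 1 to compound 3 and a 37-fold higher number (1.57 log units; beyond the scatter) from compound 2 to compound 4, at least 84-fold (1.92 log units) apart, beyond the scatter of two such steps Compound 1 gives a limit of the assay rather than a number, so the earlier step is known only as a bound, although its direction is clear: the limit of > 20000 nM in this assay, at which 1 of the 4 values shown sits. The result does not show why the two steps part, nor which difference between the cores sets them apart, the 2-fluorophenyl against the 4-fluorophenyl group or the second methoxy group of compound 1.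

The compounds shown leave open how the change behaves on a core with an unsubstituted phenyl or a 2-chlorophenyl group. They also leave open whether an ethoxy group or a longer chain on that oxygen, or an amine in its place, would keep the low number of compound 2.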